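The compounds below may be only part of what the source reports. "The series", "measured", "known", "first", "only" and "open" are said of these compounds alone.

Working notes on the series built on the shared core of compound 1 `C=C1CC[C@H]2C(C)(C)CCC[C@]2(C)[C@H]1C/C=C(\CC(=O)OCC)C(=O)O`. In a functional assay on RAW264.7 cells (Mus musculus) for inhibition, with a stated time of 24 h (on this read-out higher numbers stand for weaker inhibition and lower numbers for stronger inhibition), compound 1 gives only a limit, > 50000 nM. Compound 1 therefore sits at the limit of > 50000 nM in this assay, at which 1 of the 3 values shown sits. Compound 2 `C=C1CC[C@H]2C(C)(C)CCC[C@]2(C)[C@H]1C/C=C1\CCOC1=O` gives 30800 nM. Compound 3 `C=C1CC[C@H]2C(C)(C)CCC[C@]2(C)[C@H]1C/C=C1\CC(OC)OC1=O` gives 24600 nM, the lower of the two numbers, though compound 2 lies within the scatter of it, the change being a 1.3-fold lower number from compound 2 to compound 3 (0.10 log units; within the scatter). Compound 4 `C=C1CC[C@H]2C(C)(C)CCC[C@]2(C)[C@H]1C/C=C1\CC(OCC)OC1=O` differs from compound 3 by methyl in place of hydrogen on a saturated chain carbon bound to an oxygen on a saturated carbon. Going by the values given here, the only measured step at this site is a 1.3-fold lower number from compound 2 to compound 3 (0.10 log units; within the scatter), which stayed within the scatter, so no step beyond the scatter is expected for the added methyl in this assay. Compound 4 is thus estimated at 20000 nM, with a range from 8000 nM to 50000 nM. The expected step is a 1.2-fold lower number from compound 3 to compound 4 (0.09 log units; within the scatter).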

Compound 4, half-maximal inhibitory concentration: 31200 nM
Beside the measured number, compound 4's estimate is 1.6-fold (0.19 log units) below it; the range from low to high includes it.
By their numbers in this assay, from the lowest: compounds 3, 2 and 4 (each within the scatter of the next). At a limit, above all of these: compound 1.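

In this assay, the added methyl leaves the series within the scatter, with a 1.3-fold higher number from compound 3 to compound 4 (0.10 log units; within the scatter), and ethoxy in place of hydrogen does the same, with a 1.0-fold higher number from compound 2 to compound 4 (0.01 log units; within the scatter). Hydrogen, methoxy and ethoxy on this saturated ring carbon are thus not told apart by this read-out, which the single earlier step could not show for a second alkoxy group. Nothing among the data gives a reason for this. Still open, going by these compounds, is whether an amine, a carboxylic acid or a longer chain on this saturated ring carbon would give a step beyond the scatter.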